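A few compounds are considered here, and "the series" means these few. Any claim that something is new, unique, unknown or untested is made for them only; others in the source may bear on it.

In an ADME assay on microsomes from liver (Homo sapiens) for metabolic stability, read by LC-MS, with a stated time of 30 min, tested at 1 uM (a higher number here means that more of the compound is left, a lower number that less of the compound is left), compound 1 `O=C(NCc1ccc(S(=O)(=O)c2ccccc2)cc1)c1ccc2nccn2c1` gives 77%, compound 2 `O=C(NCc1ccc(S(=O)(=O)c2ccccc2)cc1)c1cn2ccnc2cn1` gives 87% and compound 3 `O=C(NCc1ccc(S(=O)(=O)c2ccccc2)cc1)c1ccc2nncn2c1` gives 96%. Compound 1 therefore sits at the low end of these numbers, although compound 2 remains within the scatter of it. All three share the same phenyl group and differ only in the group on the carbonyl carbon.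

Compound 4 `O=C(NCc1ccc(S(=O)(=O)c2cccc(C(F)(F)F)c2)cc1)c1ccc2nccn2c1` keeps that carbonyl group of compound 1 and changes the phenyl group instead: trifluoromethyl in place of hydrogen on an aromatic carbon. In words, trifluoromethyl takes the place of hydrogen on an aromatic carbon, turning phenyl into 3-(trifluoromethyl)phenyl.

The measured steps are a number 10 percentage points higher from compound 1 to compound 2 (within the scatter), a number 19 percentage points higher from compound 1 to compound 3 (beyond the scatter) and a number 9 percentage points higher from compound 2 to compound 3 (within the scatter). Among the measured compounds shown here, none of them touches the phenyl group, and no measured compound carries a trifluoromethyl group. These steps therefore bear on the new change only indirectly, as a guide to how far the numbers can move within this small set. They give no firm direction, so the starting point remains compound 1 at 77%. The expected result is a number 7 percentage points lower from compound 1 to compound 4 (within the scatter), a step no larger than the scatter, and its direction is only a tentative guess. For compound 4 the estimated value is 70%, with an expected range from 50% to 87%.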

Compound 4, percent of the compound remaining: 26%
Estimate against measurement, compound 4: 44 percentage points above, and the stated range ends above it.
By their numbers in this assay, from the lowest: compound 4; then compounds 1, 2 and 3 (each within the scatter of the next, the first and the last beyond it).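

In this assay the phenyl group proves to be a sensitive place: going from phenyl to 3-(trifluoromethyl)phenyl gives a number 51 percentage points lower from compound 1 to compound 4 (beyond the scatter) and turns a well-retained compound into the lowest of the four. The earlier changes all lay in the group on the carbonyl carbon, and the largest of them, a number 19 percentage points higher from compound 1 to compound 3 (beyond the scatter), is smaller and runs the other way, so those compounds gave no sign that the phenyl group could matter this much for how much compound is left. No measurement available here accounts for the drop, and which part of compound 4 is lost remains unknown.

The compounds shown leave open whether a smaller group on that aromatic carbon, such as a fluorine atom or a methyl group, would cost as much, and whether a methoxy group or a nitrile would behave like trifluoromethyl. They also leave open whether the same change would do as much when made on compound 2 or compound 3.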